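Carbonyl substituent swaps on the shared core

This account rests on a few compounds, and the source may have more. Where it says the series, first, only, none or still open, it means among the compounds named here.

- compound 1 `O=C(OCc1ccccc1)SCCCCCCNC(=O)c1cc(-c2ccncc2)n[nH]1` (18200 nM)
- compound 2 `CC(C)C(=O)SCCCCCCNC(=O)c1cc(-c2ccncc2)n[nH]1` (22700 nM)
- compound 3 `C=CCOC(=O)SCCCCCCNC(=O)c1cc(-c2ccncc2)n[nH]1` (32900 nM)

All three values come from a functional assay on HCT-116 cells (Homo sapiens) for inhibition, read by MTT assay, with a stated time of 96 h; on this read-out higher numbers stand for weaker inhibition of growth and lower numbers for stronger inhibition of growth. Compound 3 stands within the scatter of both other compounds, as the two steps reaching it show (a 1.8-fold higher number from compound 1 to compound 3 (0.26 log units; within the scatter); a 1.4-fold higher number from compound 2 to compound 3 (0.16 log units; within the scatter)).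

The next compound to be read is compound 4 `CCCC(=O)SCCCCCCNC(=O)c1cc(-c2ccncc2)n[nH]1`, which carries propyl in place of allyloxy on a carbonyl carbon. Within the data shown here, two measured steps bear on this change. One exchanges isopropyl for allyloxy on a carbonyl carbon (a 1.4-fold higher number from compound 2 to compound 3 (0.16 log units; within the scatter)), and the other puts isopropyl in place of benzyloxy (a 1.2-fold higher number from compound 1 to compound 2 (0.10 log units; within the scatter)). Both are small and lie within the scatter. Among the measured compounds, the group on the carbonyl carbon of compound 2 (22700 nM) is the closest to propyl. No step beyond the scatter is therefore expected in this assay, and the expected step is small (a 1.4-fold lower number from compound 3 to compound 4 (0.16 log units; within the scatter)). For compound 4 the estimated value is 23000 nM (expected range 12000 nM to 43000 nM).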

Compound 4, concentration for 50% growth inhibition: 23500 nM
For compound 4 the middle estimate is 1.0-fold (0.01 log units) below the measured one, and the stated range covers the measured number.
By their numbers in this assay, from the lowest: compounds 1, 2, 4 and 3 (each within the scatter of the next).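

In (this assay), propyl on a carbonyl carbon whose other neighbour is sulfur stays within the scatter of all three earlier groups: allyloxy (a 1.4-fold lower number from compound 3 to compound 4 (0.15 log units; within the scatter)), isopropyl (a 1.0-fold higher number from compound 2 to compound 4 (0.02 log units; within the scatter)) and benzyloxy (a 1.3-fold higher number from compound 1 to compound 4 (0.11 log units; within the scatter)). The earlier compounds held only groups with a branch, a double bond or a ring, or an oxygen bound to the carbonyl carbon, whereas propyl has none of these, and the number still stays within the scatter, so none of these features is shown to matter at this position in this assay. No supporting data bear on why the values stay so close.

From the compounds shown here alone, whether an amine, a carboxylic acid or a longer chain on this carbonyl carbon would give a step beyond the scatter stays open. Also open, going by these compounds, is whether a change elsewhere on the shared core would make this position respond more strongly.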